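A few compounds are considered here, and "the series" means these few. Any claim that something is new, unique, unknown or untested is made for them only; others in the source may bear on it.

Compound 3 `CC1(Nc2ccc(NC(=O)c3cc(Cl)ccc3O)c(Cl)c2)CCCC1` shares its core with compound 1 `CC(=O)Nc1ccc(NC(=O)c2cc(Cl)ccc2O)c(Cl)c1` and compound 2 `CC(C)CNc1ccc(NC(=O)c2cc(Cl)ccc2O)c(Cl)c1`; the three differ only in the group on a nitrogen on an aromatic ring. In an ADME assay on A549 cells (Homo sapiens) for cytotoxicity, read by resazurin assay, with a stated time of 48 h (a higher number here means that more compound is tolerated, a lower number that less compound is tolerated), compound 2 gives 60000 nM, and compound 3 gives 157000 nM. For compound 1 the entry in this assay reads "not determined" (no result reported), so no number is known for it. For the measured compounds named here, compound 3 therefore holds the higher of the two numbers known, set apart from compound 2 by a 2.6-fold higher number from compound 2 to compound 3 (0.42 log units; beyond the scatter).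

Compound 4 `O=C(Nc1ccc(NCc2ccc(Cl)cc2)cc1Cl)c1cc(Cl)ccc1O` is the next step: 4-chlorobenzyl in place of 1-methylcyclopentyl on a nitrogen on an aromatic ring. Going by the values given here, no measured step of this kind exists among the known compounds; the only step known is that from compound 2 to compound 3, a different exchange on the same nitrogen, and it was modest. That step gives no direction for a change to 4-chlorobenzyl, so compound 4 is expected to sit near compound 3, with a 1.6-fold lower number from compound 3 to compound 4 (0.20 log units; within the scatter) expected to stay within or just beyond the scatter. Compound 4 is thus estimated at 100000 nM in this assay, with a range from 40000 nM to 250000 nM.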

Compound 4, half-maximal cytotoxic concentration: 59700 nM
Compound 4: the middle estimate sits 1.7-fold (0.22 log units) above what was measured, within the range that was stated.
By their numbers in this assay, from the lowest: compounds 4 and 2 (each within the scatter of the next); then compound 3.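

In this assay, the exchange on the nitrogen on an aromatic ring now shows a step down of the same size as the earlier step up, with a 2.6-fold lower number from compound 3 to compound 4 (0.42 log units; beyond the scatter) in this change. The step of a 1.0-fold lower number from compound 2 to compound 4 (0.00 log units; within the scatter) shows that 4-chlorobenzyl and isobutyl cannot be told apart here, even though only 4-chlorobenzyl carries a six-membered aromatic ring and a chlorine. Compound 3, with its 1-methylcyclopentyl, thus stands apart from both other numbers, and nothing at hand accounts for this.

Compound 1 has no number, so its group on this nitrogen cannot be compared with the others. Going by these compounds, whether plain cyclopentyl without the methyl, or benzyl without the chlorine, would fall with compound 3 or with compounds 2 and 4 remains open.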